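The compounds below may be only part of what the source reports. "The series", "measured", "known", "first", "only" and "open" are said of these compounds alone.

In a functional assay on K562 cells (Homo sapiens) for antiproliferative activity, read by CCK-8 assay, with a stated time of 48 h (on this read-out higher numbers stand for weaker inhibition and lower numbers for stronger inhibition), compound 1 (`O=C(CCCCCOc1cccc(-c2nnc(-c3ccccc3)s2)c1)NO`) gives 910 nM and compound 2 (`O=C(CCCCCCOc1cccc(-c2nnc(-c3ccccc3)s2)c1)NO`) gives 3200 nM as the higher of the two numbers, so compound 2 is the weaker inhibitor of this pair. Compound 3 (`O=C(CCCCCCOc1cccc(-c2nnc(-c3ccccc3Cl)s2)c1)NO`) differs from compound 2 by chloro in place of hydrogen on an aromatic carbon in the change phenyl to 2-chlorophenyl, chloro in place of hydrogen on an aromatic carbon. For the measured compounds named here, the only measured step is a 3.5-fold higher number from compound 1 to compound 2 (0.55 log units; beyond the scatter) on the saturated chain, a modest one. Going by the values given here, it does not touch this ring, and no measured compound carries a chloro, so the data give no direction for the change. A step within the scatter, or of that modest size at most, is expected in this assay for this change. The estimate means a 1.1-fold lower number from compound 2 to compound 3 (0.03 log units; within the scatter) as the expected step. For compound 3 the expected value is 3000 nM with an estimated range from 1000 nM to 9000 nM on this read-out.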

Compound 3, half-maximal inhibitory concentration: 7700 nM
Compound 3: middle estimate off by 2.6-fold (0.41 log units), on the low side; the measured number falls inside the stated range.
By their numbers in this assay, from the lowest: compound 1; then compound 2; then compound 3.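

The change phenyl to 2-chlorophenyl gives the only step shown on this ring: in this assay the chloro, ortho to a large group, brings a 2.4-fold higher number from compound 2 to compound 3 (0.38 log units; beyond the scatter), so this place is not indifferent to the change and the step runs toward weaker inhibition. Together with a 3.5-fold higher number from compound 1 to compound 2 (0.55 log units; beyond the scatter) on the saturated chain, both single changes shown run to higher numbers, each of modest size. No measurement at hand accounts for the step on this ring.

From the compounds shown here alone, whether the step belongs to chloro itself or to any group at this place stays open, and a fluoro or a methoxy in the same place would separate the two. The 2-chlorophenyl group on the shorter chain of compound 1 would show whether the two steps add.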